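The source may report more compounds than this note shows. Statements on the series, on what has been measured and on what is new or still open speak of the compounds shown alone.

The series shares one core, seen in compound 1 `CCN(CC)CCCn1c(=O)c(=Cc2ccc(F)cc2F)s/c1=C1\C(=O)Nc2ccc(Cl)cc21`, compound 2 `COc1ccc(C=c2s/c(=C3\C(=O)Nc4cc(F)ccc43)n(CCN(C)C)c2=O)cc1` and compound 3 `CN(C)CCn1c(=O)c(=Cc2ccc(O)cc2)s/c1=C1\C(=O)Nc2ccc(F)cc21`, each tested in a functional assay on HT-29 cells (Homo sapiens) for inhibition, read by MTT assay, with a stated time of 72 h; a higher number here means a weaker inhibitor, a lower number a stronger inhibitor. For compound 1 the outcome is a limit of the assay, > 200000 nM, and not a number. Compound 2 gives 2300 nM in this assay, and compound 3 gives 1480 nM in this assay; these two values lie within the usual scatter of each other, so neither compound can be set ahead of the other on the numbers shown. Compound 4 `CN(C)CCn1c(=O)c(=Cc2ccc(O)cc2)s/c1=C1\C(=O)Nc2ccc(Br)cc21` has not yet been measured. It differs from compound 3 in a single place: bromo in place of fluoro on an aromatic carbon. Among the compounds with values here, no pair of measured compounds differs in only one place, so the size of such a halogen exchange has not been observed within this set. The expectation is that the step of a 1.3-fold lower number from compound 3 to compound 4 (0.13 log units; within the scatter) stays modest, without a clear direction beyond the scatter. Compound 4 is therefore expected to give about 1100 nM in this assay, within a range from 300 nM to 4000 nM.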

Compound 4, half-maximal inhibitory concentration: 1920 nM
For compound 4 the middle estimate is 1.7-fold (0.24 log units) below the measured one; the measured number falls inside the stated range.
By their numbers in this assay, from the lowest: compounds 3, 4 and 2 (each within the scatter of the next). At a limit, above all of these: compound 1.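

The series now has its first measured change in a single place, bromo in place of fluoro on an aromatic carbon, and in this assay it amounts to a 1.3-fold higher number from compound 3 to compound 4 (0.11 log units; within the scatter). At this carbon, meta to a fused ring and para to a fused ring, the exchange of one halogen for the other therefore leaves the number within the scatter. Within the data shown here, compound 3 and compound 4 cannot be told apart on these values, which the earlier compounds, all differing in more than one place, could not show.

On these data alone, whether a group of another kind on this carbon, such as an amine or a nitrile, would move the number beyond the scatter stays open. Compound 1 stands at a limit of the assay and not at a number, so it gives no size for any step: the limit of > 200000 nM in this assay, at which 1 of the 4 values shown sits.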